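A 3-Hydroxypropyl Chain Added to Compound 1

A few compounds are considered here, and "the series" means these few. Any claim that something is new, unique, unknown or untested is made for them only; others in the source may bear on it.

Compound 1 `Cn1cc(C2=C(c3n[nH]c4ncccc34)C(=O)NC2=O)c2ccccc21`: > 100000 nM
Compound 2 `Cn1cc(C2=C(c3nn(CCCn4cccc4)c4ncccc34)C(=O)N(c3ccccc3)C2=O)c2ccccc21`: 36600 nM

Both results come from a functional assay on K562 cells (Homo sapiens) for antiproliferative activity, read by MTT assay, with a stated time of 48 h; a higher number here means a weaker inhibitor, a lower number a stronger inhibitor. Compound 1 gives > 100000 nM, which is a limit and not a number. Compound 3 `Cn1cc(C2=C(c3nn(CCCO)c4ncccc34)C(=O)NC2=O)c2ccccc21` has 3-hydroxypropyl in place of hydrogen on an aromatic nitrogen of compound 1: 3-hydroxypropyl in place of hydrogen on an aromatic nitrogen. Among the compounds with values here, no step between measured compounds is available to size this change. A modest shift toward stronger inhibition is expected, with an at least 2.2-fold lower number from compound 1 to compound 3 (0.34 log units; beyond the scatter) as the estimated step, though the result may again be only a limit. The estimate for compound 3 is 45000 nM, with an expected range of 12000 nM to 100000 nM.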

Compound 3, half-maximal inhibitory concentration: 85800 nM
Beside the measured number, compound 3's estimate is 1.9-fold (0.28 log units) below it; measured number inside the range.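

Placing 3-hydroxypropyl on this aromatic nitrogen still leaves a readable result in this assay, with compound 3 at 85800 nM as a measured number. The change amounts to an at least 1.1-fold lower number from compound 1 to compound 3 (0.06 log units; that floor lies within the scatter) and so gives no clear gain in strength. From the compounds shown here alone, the true size of the step stays unknown because compound 1 is recorded only as a limit: the limit of > 100000 nM in this assay, at which 1 of the 3 values shown sits.

Going by these compounds, whether an amine, a carboxylic acid or a longer chain on this nitrogen would give a lower number stays open. Compound 2 differs from compound 3 in more than one place and cannot settle this.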